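The source may report more compounds than this note shows. Statements on the series, on what has been measured and on what is new or still open speak of the compounds shown alone.

Working notes on the series, lipophilicity

Two compounds of the series have a number in a physicochemical assay for lipophilicity; on this read-out lower numbers stand for lower lipophilicity and higher numbers for higher lipophilicity. Compound 1 `C[C@H]1CC[C@@H]2[C@@H](OC(=O)[C@]23CC(c2c(Cl)cccc2Cl)=NO3)[C@]2(C)C(=O)C=C[C@@]12O` gives 2.67 in this assay. Compound 2 `C[C@H]1CC[C@@H]2[C@@H](OC(=O)[C@]23CC(c2ccc(F)cc2)N(c2ccccc2)O3)[C@]2(C)C(=O)C=C[C@@]12O` gives 3.35 in this assay. Compound 2 stands highest of the two numbers; its nearest neighbour is compound 1, whose number is lower by a margin beyond the usual scatter. Going by the values given here, compound 1 and compound 2 differ in more than one place, so no single step between them is available, and the gap is read only as what the two values show.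

Compound 3 `C[C@H]1CC[C@@H]2[C@@H](OC(=O)[C@]23CC(c2cccc(F)c2)N(c2ccccc2)O3)[C@]2(C)C(=O)C=C[C@@]12O` has no number in this assay yet. Compound 3 differs from compound 2 by 3-fluorophenyl in place of 4-fluorophenyl on a saturated ring carbon. The group that leaves and the group that enters have the same atoms, joined differently, and the change is confined to a single ring.

Expectation: the step from compound 2 to compound 3 in this assay is estimated to be small, in no particular direction, and within the scatter of repeated measurements; the expected step is no change at the digits printed from compound 2 to compound 3 (within the scatter). For compound 3 the estimated value in this assay is 3.35, with a range from 3.05 to 3.65.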

Compound 3, partition coefficient: 3.35
The estimate for compound 3 equals the measured number at the digits printed; measured number inside the range.
By their numbers in this assay, from the lowest: compound 1; then compounds 2 and 3 (each within the scatter of the next).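

In this assay, 3-fluorophenyl in place of 4-fluorophenyl on the saturated ring carbon gives no change at the digits printed from compound 2 to compound 3 (within the scatter) as the only single-place step among the compounds shown. At this position, next to the ring nitrogen, the read-out therefore does not separate the two fluorophenyl groups, something compounds 1 and 2 could not show, as they differ in more than one place. No measurement at hand bears on why the two groups read alike.

As far as these compounds go, the step covers only an exchange between two groups with the same atoms, so it remains open whether the read-out would stay as flat with a different kind of group at this ring carbon, such as an aminophenyl, a carboxyphenyl or a longer alkyl chain. Also open, from the compounds shown here alone, is how the gap between compound 1 and compound 2 divides among the places in which they differ, and whether replacing the phenyl group on the ring nitrogen with a pyridyl group would shift the number.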